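Swapping trifluoromethoxy for trifluoromethyl on a weak core

The compounds below may be only part of what the source reports. "The series", "measured", "known", "first", "only" and "open" are said of these compounds alone.

Compound 2 `Cc1[nH]nc(N)c1-c1cccc(OC(F)(F)F)c1` has been tested in an assay on Sf9 cells for inhibition of mitogen-activated protein kinase kinase kinase 14 (Homo sapiens), read by ADP-Glo, with a stated time of 60 min; on this read-out higher numbers stand for weaker inhibition and lower numbers for stronger inhibition. There compound 2 gives > 100000 nM, which is a limit of the assay rather than a number. Compound 1 `Cc1[nH]nc(N)c1-c1cccc(Cl)c1` has been tested in this assay as well, and compound 1 gives > 100000 nM, likewise a limit. The step that the two limits leave unreadable from compound 1 to compound 2 cannot be read because of the limit of > 100000 nM in this assay, at which 2 of the 2 values shown sit. Compound 3 `Cc1[nH]nc(N)c1-c1cccc(C(F)(F)F)c1` differs from compound 2 by trifluoromethyl in place of trifluoromethoxy on an aromatic carbon. Among the measured compounds shown here, only that unreadable step bears on this change, so no direction beyond the scatter can be foreseen. Compound 3 is expected at 100000 nM, within 30000 nM to 300000 nM, most likely again a limit. The expected step of a number no higher from compound 2 to compound 3 (the limit leaves the size open) is therefore close to none.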

Compound 3, half-maximal inhibitory concentration: > 100000 nM
Compound 3 gave a limit, no number; the forecaster's own chance of this, stated with the estimate: 85%; the middle value lies on the limit itself.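

The steps among compound 1, compound 2 and compound 3 cannot be read, because all three stop at the same limit: the limit of > 100000 nM in this assay, at which 3 of the 3 values shown sit. Going by these compounds, whether chloro, trifluoromethoxy and trifluoromethyl differ at all on this shared core stays open.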